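A few compounds are considered here, and "the series" means these few. Any claim that something is new, unique, unknown or untested is made for them only; others in the source may bear on it.

The series shares one core, carried by compound 1 `COc1cc(OC)cc(C(=O)Nc2cc(-c3ccccc3)nn2-c2ccccc2)c1`, compound 2 `Cc1ccc(C(=O)Nc2cc(-c3ccccc3)nn2-c2ccccc2)cc1C`, compound 3 `O=C(Nc1cc(-c2ccccc2)nn1-c1ccccc1Cl)c1ccccc1` and the unmeasured compound 4 `COc1cccc(-n2nc(-c3ccccc3)cc2NC(=O)c2ccccc2)c1`. Among the compounds with values here, in a functional assay on cells for positive allosteric modulation of metabotropic glutamate receptor 5 (Rattus norvegicus), read by calcium flux (a lower number here means that less compound is needed, a higher number that more compound is needed for the effect), compound 1 gives 2040 nM, while compound 2 gives 20 nM; the step of a 100-fold lower number from compound 1 to compound 2 (2.01 log units; beyond the scatter) is the only single change measured so far, a 3,4-dimethylphenyl in place of a 3,5-dimethoxyphenyl on the carbonyl carbon. In this assay compound 3 gives 62 nM, the second highest of the three numbers, standing much nearer to compound 2 than to compound 1. Compound 4 differs from compound 3 by 3-methoxyphenyl in place of 2-chlorophenyl on an aromatic nitrogen. Within the data shown here, no measured step touches the aryl on that nitrogen, so the large step of a 100-fold lower number from compound 1 to compound 2 (2.01 log units; beyond the scatter) on the carbonyl side gives no direct guide, and the change in compound 4 is judged likely to move the number only modestly, if at all. Compound 4 is therefore expected to give 80 nM, within a range from 20 nM to 320 nM, which would mean an expected step of a 1.3-fold higher number from compound 3 to compound 4 (0.11 log units; within the scatter) that stays within the scatter.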

Compound 4, half-maximal effective concentration: 570 nM
For compound 4 the middle estimate is 7.1-fold (0.85 log units) below the measured one, outside the stated range (above it).
By their numbers in this assay, from the lowest: compound 2; then compound 3; then compound 4; then compound 1.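

Replacing 2-chlorophenyl with 3-methoxyphenyl on the aromatic nitrogen gives a 9.2-fold higher number from compound 3 to compound 4 (0.96 log units; beyond the scatter) in this assay, which shows that the number responds to the aryl at this position and not only to the group on the carbonyl carbon. The entering group differs from the leaving one in its substituent and in that substituent's place on the phenyl ring, and it also brings the only hydrogen-bond acceptor counted in either group, so this single step cannot separate these differences. Nothing available explains the step.

As far as these compounds go, it remains open whether 3-chlorophenyl or 2-methoxyphenyl on that nitrogen would follow compound 3 or compound 4, and how an unsubstituted phenyl would compare with both. Also open, from the compounds shown here alone, is how an amine or a carboxylic acid on that ring would fare.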